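Aryl replacement of the pyrimidine methyl and NF-kappa-B inhibition

The compounds below may be only part of what the source reports. "The series", "measured", "known", "first", "only" and "open" are said of these compounds alone.

The series shares the core of compound 1 `CCOC(=O)c1cnc(C)nc1NN1C(=O)C=C(C)C1=O`, which in a functional assay on Jurkat cells for inhibition of nuclear factor NF-kappa-B complex (Homo sapiens) (a higher number here means a weaker inhibitor, a lower number a stronger inhibitor), gives 16000 nM. Going by the values given here, compound 1 has the highest of the three numbers measured so far; its nearest neighbour is compound 3 `CCOC(=O)c1cnc(-c2csc(C)n2)nc1NN1C(=O)C=C(C)C1=O` with 8000 nM, and the furthest is compound 2 `CCOC(=O)c1cnc(-c2cccs2)nc1NN1C(=O)C=C(C)C1=O` with 20 nM.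

Compound 4 `CCOC(=O)c1cnc(-n2nc(C)cc2C)nc1NN1C(=O)C=C(C)C1=O` differs from compound 1 in one place: 3,5-dimethyl-1H-pyrazol-1-yl in place of methyl on an aromatic carbon.

Among the compounds with values here, two measured steps bear on this change, both replacing the same methyl with a five-membered aromatic ring. The step of an 800-fold lower number from compound 1 to compound 2 (2.90 log units; beyond the scatter) is large, whereas the step of a 2.0-fold lower number from compound 1 to compound 3 (0.30 log units; within the scatter) lies within the scatter. Which of these compound 4 follows is not known; a ring with two nitrogen atoms and two methyl groups has no precedent here, and the step of a 400-fold higher number from compound 2 to compound 3 (2.60 log units; beyond the scatter) shows that the identity of the five-membered ring decides most of the outcome. A moderate improvement is expected for compound 4, short of the step seen for compound 2, with a wide range.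

For compound 4 the expected step is a 4.0-fold lower number from compound 1 to compound 4 (0.60 log units; beyond the scatter), giving an estimate of 4000 nM, between 400 nM and 30000 nM.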

Compound 4, half-maximal inhibitory concentration: 10000 nM
Beside the measured number, compound 4's estimate is 2.5-fold (0.40 log units) below it; the measured number falls inside the stated range.
By their numbers in this assay, from the lowest: compound 2; then compounds 3, 4 and 1 (each within the scatter of the next).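

In this assay the 3,5-dimethyl-1H-pyrazol-1-yl group reads no differently from methyl (a 1.6-fold lower number from compound 1 to compound 4 (0.20 log units; within the scatter)) or from the 2-methyl-1,3-thiazol-4-yl group (a 1.3-fold higher number from compound 3 to compound 4 (0.10 log units; within the scatter)). Going by these compounds alone, this gives a second five-membered aromatic ring on the aromatic carbon between two ring nitrogen atoms with no readable gain over methyl, so having such a ring at this position is not enough on its own; compound 2 is the one compound that goes against this. Its thiophen-2-yl group now stands apart from two different rings (a 500-fold higher number from compound 2 to compound 4 (2.70 log units; beyond the scatter)), and compound 2 is the strongest inhibitor of the four, its steps to all the others lying beyond the scatter.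

Compounds 3 and 4 both carry ring nitrogen and methyl on the five-membered ring while compound 2 carries neither, so the compounds shown leave open which of these features separates them; a methyl-bearing thiophen-2-yl, an unsubstituted pyrazol-1-yl, a phenyl or an amine at this place would bear on that question. Nothing available accounts for the isolated result of the thiophen-2-yl group.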